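The source may report more compounds than this note shows. Statements on the series, on what has been measured and on what is new or still open speak of the compounds shown alone.

Measured compounds: compound 1 `Oc1ccc(-c2cc(-c3ccc(F)cc3)cc(-c3ccccc3O)n2)cc1`, compound 2 `Oc1cccc(-c2cc(-c3cccc(C(F)(F)F)c3)cc(-c3ccccc3O)n2)c1`, compound 3 `Oc1ccc(-c2cc(-c3ccccc3C(F)(F)F)cc(-c3ccccc3O)n2)cc1`.

In a functional assay on HeLa cells (Homo sapiens) for inhibition (on this read-out higher numbers stand for weaker inhibition and lower numbers for stronger inhibition), compound 3 gives 16500 nM. Compound 2 gives 19500 nM in this assay, a number within the scatter of that of compound 3. Compound 1 reaches only a limit in this assay, at > 50000 nM; this is the limit of > 50000 nM in this assay, at which 1 of the 3 values shown sits. Compound 4 `Oc1ccc(-c2cc(-c3cccc(C(F)(F)F)c3)cc(-c3ccccc3O)n2)cc1` differs from compound 3 in one place: 3-(trifluoromethyl)phenyl in place of 2-(trifluoromethyl)phenyl on an aromatic carbon. Within the data shown here, the one measured step that bears on it, an at least 3.0-fold lower number from compound 1 to compound 3 (0.48 log units; beyond the scatter), also changes the same substituent, but against a limit. Compound 2 carries the same 3-(trifluoromethyl)phenyl group on a related core and gives a number close to compound 3. For compound 4 a step of a 1.1-fold higher number from compound 3 to compound 4 (0.04 log units; within the scatter) is therefore expected, no shift beyond the scatter, with an estimate of 18000 nM in this assay, between 8000 nM and 45000 nM.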

Compound 4, half-maximal inhibitory concentration: > 50000 nM
Compound 4 ended at the assay's limit; the forecaster's own chance of this, stated with the estimate: 15%; middle value at least 2.7-fold (0.44 log units) away from the limit.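

In this assay, 3-(trifluoromethyl)phenyl in place of 2-(trifluoromethyl)phenyl gives an at least 3.0-fold higher number from compound 3 to compound 4 (0.48 log units; beyond the scatter), so at this position, opposite the ring nitrogen, the placing of the trifluoromethyl group matters although the two groups have the same atoms. With 3-(trifluoromethyl)phenyl held fixed, 4-hydroxyphenyl in place of 3-hydroxyphenyl gives an at least 2.5-fold higher number from compound 2 to compound 4 (0.40 log units; beyond the scatter), so the hydroxyl placing matters too. Compound 4 stands at a limit, as compound 1 does, and the step between them cannot be read: the limit of > 50000 nM in this assay, at which 2 of the 4 values shown sit.

As far as these compounds go, how far compound 4 lies beyond that limit stays open, so both readable steps give only a minimum size. Also open, from the compounds shown here alone, is how an amine or a carboxylic acid on the phenyl ring at this position would read.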